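One methyl group moves: compound 3 awaits its reading

This account rests on a few compounds, and the source may have more. Where it says the series, first, only, none or still open, it means among the compounds named here.

In an ADME assay on HEK293 cells (Homo sapiens) for cytotoxicity, read by resazurin assay, with a stated time of 48 h (a higher number here means that more compound is tolerated, a lower number that less compound is tolerated), compound 1 `O=S(=O)(Nc1ccc(-c2nc3ccccc3o2)cc1)c1ccc(Cl)s1` gives > 100000 nM, which is a limit of the assay and not a number. Compound 2 `Cc1ccccc1S(=O)(=O)Nc1ccc(-c2nc3ccccc3o2)cc1` gives > 100000 nM, which is also a limit. Compound 3 `Cc1cccc(S(=O)(=O)Nc2ccc(-c3nc4ccccc4o3)cc2)c1` has the same atoms as compound 2, joined differently: 3-methylphenyl in place of 2-methylphenyl on a sulfonyl sulfur, with 3-methylphenyl in place of 2-methylphenyl on a sulfonyl sulfur. Within the data shown here, only one measured step bears on this change, a step that the two limits leave unreadable from compound 1 to compound 2, so it offers no size to carry over. Both compounds of that step rest at the same point, (the limit of > 100000 nM in this assay, at which 2 of the 2 values shown sit). In this assay, no step beyond the usual scatter is therefore expected, and no direction can be given, with a step that the limit leaves unreadable from compound 2 to compound 3 as the estimate. Compound 3 is estimated at 120000 nM, within an expected range of 50000 nM to 250000 nM, and will most likely be reported as a limit again.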

Compound 3, half-maximal cytotoxic concentration: > 100000 nM
Compound 3 gave a limit, no number; the forecaster's own chance of this, stated with the estimate: 90%; the middle value is on the limit's open side.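

Compound 3, like compound 1 and compound 2, gives a limit of the assay and not a number, so no step among these three compounds can be read: the limit of > 100000 nM in this assay, at which 3 of the 3 values shown sit.

The compounds shown leave open at what concentration any of them would reach the half-maximal cytotoxic point in this assay and whether the place of the methyl group matters.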